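Swapping the aryl ketone end: a chlorophenyl variant

The source may report more compounds than this note shows. Statements on the series, on what has been measured and on what is new or still open speak of the compounds shown alone.

Measured compounds:
- Compound 1 `COc1ccc(/C=C/c2cc(OC)cc(OC)c2/C=C/C(=O)c2ccc(N)cc2)cc1`: 3.8 ug/mL
- Compound 2 `COc1ccc(/C=C/c2cc(OC)cc(OC)c2/C=C/C(=O)c2cccc(Cl)c2)cc1`: 5.6 ug/mL
- Compound 3 `COc1ccc(/C=C/c2cc(OC)cc(OC)c2/C=C/C(=O)c2cccc(OC)c2)cc1`: 6.1 ug/mL

All three share one core and differ only in the aromatic ring attached to the carbonyl carbon. In a functional assay on A549 cells (Homo sapiens) for antiproliferative activity, read by MTT assay, with a stated time of 48 h (a lower number here means a stronger inhibitor, a higher number a weaker inhibitor), compound 1 gives 3.8 ug/mL, compound 2 gives 5.6 ug/mL and compound 3 gives 6.1 ug/mL. Compound 3 has the highest of the three numbers, but every step to it lies within the scatter: a 1.6-fold higher number from compound 1 to compound 3 (0.21 log units; within the scatter) and a 1.1-fold higher number from compound 2 to compound 3 (0.04 log units; within the scatter). None of the three compounds can be called the strongest or weakest.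

Compound 4 `COc1ccc(/C=C/c2cc(OC)cc(OC)c2/C=C/C(=O)c2ccc(Cl)cc2)cc1` is not yet measured. Its change from compound 3 is 4-chlorophenyl in place of 3-methoxyphenyl on a carbonyl carbon. Within the data shown here, two measured steps bear on it. The exchange of methoxy for chloro gave a 1.1-fold higher number from compound 2 to compound 3 (0.04 log units; within the scatter), and the exchange of the whole ring in a 1.5-fold higher number from compound 1 to compound 2 (0.17 log units; within the scatter) also stayed within the scatter. Among the measured compounds shown here, no measured pair compares a 3-substituted with a 4-substituted ring bearing the same group, so that part of the change is uninformed.

The expectation for the step is therefore a 1.2-fold lower number from compound 3 to compound 4 (0.09 log units; within the scatter), which is no change beyond the scatter. Compound 4 is estimated at 5 ug/mL, with a range from 2.5 ug/mL to 10 ug/mL.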

Compound 4, half-maximal inhibitory concentration: 6.4 ug/mL
Compound 4: middle estimate off by 1.3-fold (0.11 log units), on the low side; the range from low to high includes it.
By their numbers in this assay, from the lowest: compounds 1, 2, 3 and 4 (each within the scatter of the next).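

In this assay, among these compounds, the exchange of 3-chlorophenyl for 4-chlorophenyl on the carbonyl carbon is the first pair in which the same group sits at two ring positions, and it gives a 1.1-fold higher number from compound 2 to compound 4 (0.06 log units; within the scatter) so moving chloro shows no readable effect here. The two other new comparisons also stay inside the scatter, with a 1.0-fold higher number from compound 3 to compound 4 (0.02 log units; within the scatter) for the exchange of the whole ring and a 1.7-fold higher number from compound 1 to compound 4 (0.23 log units; within the scatter) for chloro in place of amino, so the four ring variants cannot be told apart in this assay. No measurement at hand offers an explanation for any of these steps.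

Going by these compounds, whether a carboxylic acid or a dimethylamino group on this ring, or a saturated cyclohexyl ring in its place, would give a step beyond the scatter stays open. The compounds shown also leave open whether amino and methoxy would behave as chloro does, since 3-aminophenyl and 4-methoxyphenyl do not appear among them.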